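Working Notes: Stability Step from Compound 2 to Compound 3

The compounds below may be only part of what the source reports. "The series", "measured", "known", "first", "only" and "open" are said of these compounds alone.

For the measured compounds named here, compound 2 `CCCCCCCCc1ccc(OCC(=O)Cn2nnnc2C)cc1` holds the only numerical value in an ADME assay on S9 fraction from liver (Rattus norvegicus) for metabolic stability, read by LC-MS, using NADPH, with a stated time of 30 min (a higher number here means that more of the compound is left, a lower number that less of the compound is left), where compound 2 gives 32%. Compound 1 `CCCCCCCCc1ccc(OCC(=O)Cn2nnc(SC)n2)cc1` sits at a limit of this assay, giving < 5%. Going by the values given here, the single measured step, a number at least 27 percentage points higher from compound 1 to compound 2 (beyond the scatter), changes a group on a ring nitrogen, so it bears only indirectly on the present change. Compound 3 `CCCCCCCCc1ccc(OCC(=O)Cn2nnnc2-c2ccc(C(=O)O)cc2)cc1` differs from compound 2 by 4-carboxyphenyl in place of methyl on an aromatic carbon. Among the compounds with values here, no measured step changes a group on an aromatic carbon. The step of a number 13 percentage points higher from compound 2 to compound 3 (beyond the scatter) is expected to be modest and upward. Compound 3 is estimated at 45%, within 20% to 75%.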

Compound 3, percent of the compound remaining: 6%
Beside the measured number, compound 3's estimate is 39 percentage points above it; measured number outside the range, below it.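

In this assay, the aromatic carbon between two ring nitrogen atoms proves sensitive to the group it carries, with 4-carboxyphenyl in place of methyl giving a number 26 percentage points lower from compound 2 to compound 3 (beyond the scatter). On this carbon, the larger group leaves less of the compound, so size added here brings no gain in the one case shown. Any further loss at this position would have little room to appear: the limit of < 5% in this assay, at which 1 of the 3 values shown sits.

As far as these compounds go, whether the step belongs to the phenyl ring or to its carboxylic acid stays open. A plain phenyl on this carbon would separate the two.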